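Ester side chain variation on the shared anilide core

The source may hold more compounds than are shown below. What is called first, only, known or untested is meant among the compounds shown, and "the series" means these compounds.

Measured so far in a functional assay for inhibition, read by spectrophotometry, tested at 200 ug/mL; a higher number here means more inhibition at the concentration tested (going by the name of the read-out), a lower number less inhibition:
compound 1 `CCOC(=O)CCCOc1ccc(NC(=O)COc2ccc3ccccc3c2)cc1`, 27%
compound 2 `CCOC(=O)C(C)Oc1ccc(NC(=O)COc2ccc3ccccc3c2)cc1`, 25%

Compound 2 sits at the bottom of these two numbers, yet the step of a number 2 percentage points lower from compound 1 to compound 2 (within the scatter) is within the scatter, so the two side chains are not separated in this assay.

Compound 3 `CCOC(=O)C(C)(C)Oc1ccc(NC(=O)COc2ccc3ccccc3c2)cc1` differs from compound 2 by methyl in place of hydrogen on a saturated chain carbon bound to a carbonyl carbon, an oxygen on an aromatic ring and a saturated chain carbon.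

Among the measured compounds shown here, only the step from compound 1 to compound 2 bears on this change, a different alteration of the same ester side chain, and it was within the scatter. A step within the scatter is therefore expected for compound 3 as well, no change at the digits printed from compound 2 to compound 3 (within the scatter).

The estimate for compound 3 in this assay is 25%, expected between 12% and 40%.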

Compound 3, a percentage reported as inhibition, at one concentration (the size of the read-out at that concentration, not a potency): 30%
For compound 3 the middle estimate is 5 percentage points below the measured one; the measured number falls inside the stated range.
By their numbers in this assay, from the lowest: compounds 2, 1 and 3 (each within the scatter of the next).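

In this assay, methyl in place of hydrogen on this saturated chain carbon gives a number 5 percentage points higher from compound 2 to compound 3 (within the scatter), so filling this carbon with a further methyl does not separate the two side chains. The 1-(ethoxycarbonyl)-1-methylethyl group in place of 3-(ethoxycarbonyl)propyl gives a number 3 percentage points higher from compound 1 to compound 3 (within the scatter), which leaves all three ester side chains unseparated in this assay. Open, going by these compounds, is whether a carboxylic acid in place of the ethyl ester, or an amine on this side chain, would give a step beyond the scatter. No independent data bear on this result.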